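A Chloro Substituent Takes the Place of the Nitro Group

The compounds below may be only part of what the source reports. "The series", "measured", "known", "first", "only" and "open" are said of these compounds alone.

Compound 1, `Nc1scc(CN2CCN(c3cc(Cl)cc(Cl)c3)CC2)c1C(=O)c1ccc(Cl)cc1`: -22%
Compound 2, `Nc1scc(CN2CCN(c3ccc([N+](=O)[O-])cc3)CC2)c1C(=O)c1ccc(Cl)cc1`: -13%
Compound 3, `Nc1scc(CN2CCN(c3cccc(F)c3)CC2)c1C(=O)c1ccc(Cl)cc1`: -37%

Of the compounds shown here, three have been measured in a functional assay on CHO cells with adenosine receptor A1 (Homo sapiens) as the target, read by cAMP accumulation and immunoassay, with a stated time of 6 min, tested at 0.1 uM; on this read-out higher numbers stand for a weaker effect at the one concentration tested and lower numbers for a stronger effect. Compound 2 stands highest of the three numbers; the nearest step is a number 9 percentage points higher from compound 1 to compound 2 (within the scatter) and the furthest is a number 24 percentage points lower from compound 2 to compound 3 (beyond the scatter). Compound 4, `Nc1scc(CN2CCN(c3cccc(Cl)c3)CC2)c1C(=O)c1ccc(Cl)cc1`, has not yet been measured. It differs from compound 2 by 3-chlorophenyl in place of 4-nitrophenyl on an amine nitrogen in a ring. Among the compounds with values here, two measured steps bear on this change: a number 24 percentage points lower from compound 2 to compound 3 (beyond the scatter), and a number 15 percentage points lower from compound 1 to compound 3 (beyond the scatter), in both of which the 3-fluorophenyl compound gave the lower number. A halogen on a phenyl ring is thus expected to bring the number down from compound 2, though the size for a chlorine is uncertain. For compound 4 the expected step is a number 17 percentage points lower from compound 2 to compound 4 (beyond the scatter). For compound 4 the estimate in this assay is -30%, ranging from -45% to -15%.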

Compound 4, a percentage reported as activity, at one concentration (the size of the read-out at that concentration, not a potency): -20%
Compound 4: middle estimate off by 10 percentage points, on the low side; measured number inside the range.
By their numbers in this assay, from the lowest: compound 3; then compounds 1, 4 and 2 (each within the scatter of the next).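

Set against the 4-nitrophenyl group, the 3-chlorophenyl group gives no clear separation in this assay (a number 7 percentage points lower from compound 2 to compound 4 (within the scatter)), so a halogen on this phenyl ring does not by itself lower the number. The choice of halogen does count, since chloro in place of fluoro gives a number 17 percentage points higher from compound 3 to compound 4 (beyond the scatter), while hydrogen in place of chloro on the dichlorophenyl ring leaves a number 2 percentage points higher from compound 1 to compound 4 (within the scatter). Nothing at hand explains the gap between fluoro and chloro. Open, on these data alone, is how a bromo or methoxy group on this phenyl ring would read, or a pyridine in its place.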